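Swapping furan for pyrrole on the shared core

This account rests on a few compounds, and the source may have more. Where it says the series, first, only, none or still open, it means among the compounds named here.

Measured in a functional assay on A-375 cells (Homo sapiens) for activation, with a stated time of 3 days; on this read-out lower numbers stand for an effect already at smaller amounts and higher numbers for an effect only at larger amounts of compound:
- Compound 1 `O=C(Nc1ccc(-c2nccs2)cc1)C1CCCN(Cc2ccc(F)c(F)c2)C1`: 800 nM
- Compound 2 `O=C(Nc1ccc(-c2ncc[nH]2)cc1)C1CCCN(Cc2ccc(F)c(F)c2)C1`: 8000 nM
- Compound 3 `O=C(Nc1ccc(-c2ccoc2)cc1)C1CCCN(Cc2ccc(F)c(F)c2)C1`: 3000 nM

Compound 3, at 3000 nM, sits in the middle of these three numbers. Only the group on the aromatic ring differs among them, and each swap moved the number beyond the usual scatter: a 10-fold higher number from compound 1 to compound 2 (1.00 log units; beyond the scatter), a 3.8-fold higher number from compound 1 to compound 3 (0.57 log units; beyond the scatter) and a 2.7-fold lower number from compound 2 to compound 3 (0.43 log units; beyond the scatter).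

The next compound is compound 4 `O=C(Nc1ccc(-c2ccc[nH]2)cc1)C1CCCN(Cc2ccc(F)c(F)c2)C1`, which carries 1H-pyrrol-2-yl in place of furan-3-yl on an aromatic carbon. For the measured compounds named here, no measured compound carries this group. Its nearest measured relative is the 1H-imidazol-2-yl of compound 2, so the step that bears most directly is a 2.7-fold lower number from compound 2 to compound 3 (0.43 log units; beyond the scatter), a modest one. Compound 4 is therefore expected to fall between compound 3 and compound 2, closer to compound 3, in this assay. The expected change is small and in the direction of a higher number, a 1.3-fold higher number from compound 3 to compound 4 (0.12 log units; within the scatter), and may not exceed the scatter. For compound 4 the estimated value is 4000 nM, with an expected range of 1500 nM to 10000 nM.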

Compound 4, half-maximal effective concentration: 720 nM
Compound 4: the middle estimate sits 5.6-fold (0.74 log units) above what was measured; measured number outside the range, below it.
By their numbers in this assay, from the lowest: compounds 4 and 1 (each within the scatter of the next); then compound 3; then compound 2.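

Moved from furan-3-yl to 1H-pyrrol-2-yl in this assay, this position shows that exchanging one five-membered aromatic ring for another with a single hetero atom can still shift the result clearly (a 4.2-fold lower number from compound 3 to compound 4 (0.62 log units; beyond the scatter)). Two rings that both contain nitrogen also end far apart (an 11-fold lower number from compound 2 to compound 4 (1.05 log units; beyond the scatter)), so the presence of nitrogen in the ring does not by itself set the number. The 1H-pyrrol-2-yl group and the 1,3-thiazol-2-yl group cannot be told apart here (a 1.1-fold lower number from compound 1 to compound 4 (0.05 log units; within the scatter)), which gives this position two different rings at the low end of the series.

As far as these compounds go, it remains open whether a six-membered pyridine ring, an amine or a carboxylic acid on this aromatic carbon would keep the number as low. No measurement shown here explains the differences among these rings.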